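The source may report more compounds than this note shows. Statements on the series, on what has been measured and on what is new or still open speak of the compounds shown alone.

Compound 1 `Cn1cc(C2=C(c3nn(CCCn4cncn4)c4ncccc34)C(=O)NC2=O)c2ccccc21` is the starting point here, tested in a functional assay on A549 cells (Homo sapiens) for antiproliferative activity, read by MTT assay, with a stated time of 48 h; a higher number here means a weaker inhibitor, a lower number a stronger inhibitor. In that test compound 1 gives > 100000 nM, which is a limit of the assay and not a number. This puts it at the limit of > 100000 nM in this assay, at which 1 of the 3 values shown sits. The other two compounds do give numbers: compound 2 `Cn1cc(C2=C(c3nn(CCCN4CCCCC4)c4ncccc34)C(=O)N(c3ccc(Cl)cc3)C2=O)c2ccccc21` reads 28700 nM, and compound 3 `CN(C)CCCn1nc(C2=C(c3cn(C)c4ccccc34)C(=O)N(c3ccccc3)C2=O)c2cccnc21` reads 13000 nM. Both differ from compound 1 in more than one place, so neither isolates a single structural change.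

Compound 4 `Cn1cc(C2=C(c3nn(CCCCn4ccnc4)c4ncccc34)C(=O)NC2=O)c2ccccc21` keeps the core of compound 1 and changes only the side chain. (1H-imidazol-1-yl)methyl takes the place of 1H-1,2,4-triazol-1-yl on a saturated chain carbon, three bonds along the chain from an aromatic nitrogen, so that 3-(1H-1,2,4-triazol-1-yl)propyl becomes 4-(1H-imidazol-1-yl)butyl ((1H-imidazol-1-yl)methyl in place of 1H-1,2,4-triazol-1-yl on a saturated chain carbon, three bonds along the chain from an aromatic nitrogen). Among the measured compounds shown here, no measured pair shows what a swap of this kind does in this assay, so the expectation starts from compound 1 and assumes no clear shift in either direction. The expected change, an at least 1.1-fold lower number from compound 1 to compound 4 (0.07 log units; that floor lies within the scatter), is estimated to stay within the usual scatter. The result could well be reported as a limit again. For compound 4 the estimated value is 85000 nM, with an expected range of 40000 nM to 130000 nM.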

Compound 4, half-maximal inhibitory concentration: 2380 nM
Beside the measured number, compound 4's estimate is 36-fold (1.55 log units) above it, and the stated range ends above it.
By their numbers in this assay, from the lowest: compound 4; then compound 3; then compound 2. At a limit, above all of these: compound 1.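

In this assay, the side chain proves able to move the result by a wide margin: with the core of compound 1 left unchanged, replacing 3-(1H-1,2,4-triazol-1-yl)propyl with 4-(1H-imidazol-1-yl)butyl gives an at least 42-fold lower number from compound 1 to compound 4 (1.62 log units; beyond the scatter). Among the compounds shown here, this is the first step here that isolates a change in one place, and compound 1 alone could not show whether this side chain had any influence on the read-out. The true size of the step remains unknown, and the printed figure is only a floor, because compound 1 stands at a limit of the assay: the limit of > 100000 nM in this assay, at which 1 of the 4 values shown sits.

The swap alters the ring and the chain length together, so these compounds cannot show whether the gain belongs to the imidazole ring, the longer chain, or both; 3-(1H-imidazol-1-yl)propyl and 4-(1H-1,2,4-triazol-1-yl)butyl on the same core would separate the two effects. Also open, as far as these compounds go, is how this core would respond to a still longer chain, such as 5-(1H-imidazol-1-yl)pentyl, or to a morpholine ring at the chain end.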